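Moving the Fluorine on the Higher-Reading Core

The compounds below may be only part of what the source reports. "The series", "measured", "known", "first", "only" and "open" are said of these compounds alone.

Of the compounds shown here, three have been measured in an assay on isolated protein for inhibition of DNA topoisomerase 1 (Homo sapiens), with a stated time of 30 min, tested at 100 uM; on this read-out lower numbers stand for less inhibition and higher numbers for more inhibition at the one concentration tested (going by the name of the read-out). Compound 1 `O=C(/C=C/c1cccc(F)c1)Nc1ccc(CC2=CC(=O)OC2)cc1` gives 13.1% in this assay, and compound 2 `O=C(/C=C/c1ccccc1F)Nc1ccc(CC2=CC(=O)OC2)cc1` gives 11.7%. The change between them is 2-fluorophenyl in place of 3-fluorophenyl on a double-bonded chain carbon bound to a double-bonded chain carbon, and it made a number 1.4 percentage points lower from compound 1 to compound 2 (within the scatter). Compound 3 `C=C1OC(=O)C=C1Cc1ccc(NC(=O)/C=C/c2cccc(F)c2)cc1` differs from compound 1 in its core by a group of 7 heavy atoms (5 carbon, 2 oxygen; one five-membered non-aromatic ring with 1 hetero atom) in place of a group of 6 heavy atoms (4 carbon, 2 oxygen; one five-membered non-aromatic ring with 1 hetero atom), on a saturated chain carbon bound to an aromatic carbon, and this gave a number 21.4 percentage points higher from compound 1 to compound 3 (beyond the scatter); compound 3 gives 34.5% in this assay, the highest of the three numbers, with the steps to compound 1 and compound 2 both beyond the scatter.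

Compound 4 `C=C1OC(=O)C=C1Cc1ccc(NC(=O)/C=C/c2ccccc2F)cc1` has not yet been measured. It differs from compound 3 by 2-fluorophenyl in place of 3-fluorophenyl on a double-bonded chain carbon bound to a double-bonded chain carbon, the same change that carried compound 1 to compound 2, made here on the core of compound 3. Because that change made a number 1.4 percentage points lower from compound 1 to compound 2 (within the scatter) on the core of compound 1, a similarly small step is expected here, a number 1.5 percentage points lower from compound 3 to compound 4 (within the scatter). On this basis compound 4 is estimated to give 33% in this assay, with an expected range from 20% to 46%.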

Compound 4, a percentage reported as inhibition, at one concentration (the size of the read-out at that concentration, not a potency): 44.6%
Compound 4: the middle estimate sits 11.6 percentage points below what was measured; measured number inside the range.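

In this assay, the swap to 2-fluorophenyl gave a number 10.1 percentage points higher from compound 3 to compound 4 (beyond the scatter), whereas on the core of compound 1 it gave a number 1.4 percentage points lower from compound 1 to compound 2 (within the scatter), yet these two steps cannot be told apart: the same change on two cores in this assay, a number 1.4 percentage points lower (within the scatter) from compound 1 to compound 2 and a number 10.1 percentage points higher (beyond the scatter) from compound 3 to compound 4, 11.5 percentage points apart, within the scatter of two such steps. The change of core, read on the 2-fluorophenyl pair, gave a number 32.9 percentage points higher from compound 2 to compound 4 (beyond the scatter), and this also agrees with the step seen on the 3-fluorophenyl pair: the same change on two cores in this assay, a number 21.4 percentage points higher (beyond the scatter) from compound 1 to compound 3 and a number 32.9 percentage points higher (beyond the scatter) from compound 2 to compound 4, 11.5 percentage points apart, within the scatter of two such steps. Within these four compounds, both changes therefore carry from one setting to the other with no gap beyond the scatter, but a single pair of steps does not show that the fluorine swap acts identically on every core, nor that its outcome depends on the core.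

From the compounds shown here alone, whether a plain phenyl or a chlorophenyl in the same place would fit this picture remains open. These readings at one concentration also leave open how the compounds compare in potency.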